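3-Hydroxypropoxy to 2-hydroxyethoxy: expected effect

The compounds below may be only part of what the source reports. "The series", "measured", "known", "first", "only" and "open" are said of these compounds alone.

compound 1 `Cc1cc2ccccc2n1CCNC(=O)/C=C/c1ccc(OCCO)c(OCCO)c1` — 11.4 nM
compound 2 `Cc1cc2ccccc2n1CCNC(=O)/C=C/c1ccc(OCCCO)cc1` — 11.8 nM

In an assay on C6 cells for antagonist activity at prostaglandin E2 receptor EP2 subtype (Homo sapiens), read by TR-FRET, with stated times of 10 min and 40 min, tested at 1 uM (a lower number here means a stronger inhibitor, a higher number a weaker inhibitor), compound 1 gives 11.4 nM and compound 2 gives 11.8 nM. Compound 2 holds the higher of the two numbers, yet its gap to compound 1 lies within the scatter, so the two cannot be told apart. Compound 3 `Cc1cc2ccccc2n1CCNC(=O)/C=C/c1ccc(OCCO)cc1` differs from compound 2 by hydroxy in place of hydroxymethyl on a saturated chain carbon, two bonds along the chain from an oxygen on an aromatic ring. Going by the values given here, no measured pair shows this exact change. Compound 1, which also carries a 2-hydroxyethoxy group, gives 11.4 nM, so little movement beyond the scatter is expected. The step of a 1.2-fold higher number from compound 2 to compound 3 (0.07 log units; within the scatter) is expected to be small, direction uncertain. Compound 3 is expected at 14 nM, within 6 nM to 35 nM.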

Compound 3, antagonist equilibrium constant in the prostaglandin E2 receptor EP2 subtype assay: 13.6 nM
For compound 3 the middle estimate is 1.0-fold (0.01 log units) above the measured one, and the stated range covers the measured number.
By their numbers in the prostaglandin E2 receptor EP2 subtype assay, from the lowest: compounds 1, 2 and 3 (each within the scatter of the next).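

In the prostaglandin E2 receptor EP2 subtype assay the exchange of 3-hydroxypropoxy for 2-hydroxyethoxy reads a 1.2-fold higher number from compound 2 to compound 3 (0.06 log units; within the scatter) and the loss of the second 2-hydroxyethoxy group reads a 1.2-fold higher number from compound 1 to compound 3 (0.08 log units; within the scatter), so neither change separates these compounds. In a physicochemical assay for solubility, read by nephelometry, in phosphate buffer, at pH 7.4 (a higher number here means a more soluble compound, a lower number a less soluble compound), compound 2 gives 66000 nM and compound 3 gives 68000 nM, so the same exchange reads a 1.0-fold higher number from compound 2 to compound 3 (0.01 log units; within the scatter) and again separates nothing. No supporting evidence bears on these results.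

Still open, on these data alone, is whether an amine or a carboxylic acid in place of the hydroxy, or a longer chain, would move the number in the prostaglandin E2 receptor EP2 subtype assay beyond the scatter.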